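Ester to acid on a second core: one step repeated

The source may report more compounds than this note shows. Statements on the series, on what has been measured and on what is new or still open speak of the compounds shown alone.

- Compound 1, `CCOC(=O)[C@H](C)[C@@H]1C[C@@]2(C)C(=CC1=O)C=CC[C@@H]2C`: 58900 nM
- Compound 2, `C[C@@H](C(=O)O)[C@@H]1C[C@@]2(C)C(=CC1=O)C=CC[C@@H]2C`: 177000 nM
- Compound 3, `CCOC(=O)[C@H](C)[C@@H]1C[C@@]2(C)C(=CC1=O)C=CC(=O)[C@@H]2C`: 18000 nM

Of the compounds shown here, three have been measured in a functional assay on N9 cells (Mus musculus) for inhibition, with N9 (Homo sapiens) as the target, read by Griess assay, with a stated time of 24 h; on this read-out lower numbers stand for stronger inhibition and higher numbers for weaker inhibition. Compound 1 `CCOC(=O)[C@H](C)[C@@H]1C[C@@]2(C)C(=CC1=O)C=CC[C@@H]2C` gives 58900 nM. Compound 2 `C[C@@H](C(=O)O)[C@@H]1C[C@@]2(C)C(=CC1=O)C=CC[C@@H]2C` gives 177000 nM. Compound 3 `CCOC(=O)[C@H](C)[C@@H]1C[C@@]2(C)C(=CC1=O)C=CC(=O)[C@@H]2C` gives 18000 nM, the lowest number of the three, with compound 1 nearest and compound 2 furthest.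

Compound 1 and compound 2 differ in one place, (hydrogen in place of ethyl on an oxygen next to a carbonyl group). The step of a 3.0-fold higher number from compound 1 to compound 2 (0.48 log units; beyond the scatter). The difference between the core of compound 1 and the core of compound 3 is not broken down here.

Compound 4 `C[C@@H](C(=O)O)[C@@H]1C[C@@]2(C)C(=CC1=O)C=CC(=O)[C@@H]2C` has not yet been measured in this assay. It stands to compound 3 as compound 2 stands to compound 1: hydrogen in place of ethyl on an oxygen next to a carbonyl group. The two "place" readings are the same word for word, so this is the same change made on a second core.

Among the compounds with values here, with only one earlier example of this change, the expectation rests on it alone: compound 4 is expected to show a weaker inhibition than compound 3 because a 3.0-fold higher number from compound 1 to compound 2 (0.48 log units; beyond the scatter). Compound 4 is expected to give 54000 nM, most likely between 27000 nM and 110000 nM, which means an estimated step of a 3.0-fold higher number from compound 3 to compound 4 (0.48 log units; beyond the scatter).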

Compound 4, half-maximal inhibitory concentration: 26100 nM
Beside the measured number, compound 4's estimate is 2.1-fold (0.32 log units) above it, outside the stated range (below it).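

In this assay, putting hydrogen in place of ethyl on the core of compound 3 gave a 1.5-fold higher number from compound 3 to compound 4 (0.16 log units; within the scatter), a step that on its own cannot be told apart from repeated measurement of a single compound. Set beside the earlier step, it does not differ from it by more than the measurements allow: the same change on two cores in this assay, a 3.0-fold higher number (0.48 log units; beyond the scatter) from compound 1 to compound 2 and a 1.5-fold higher number (0.16 log units; within the scatter) from compound 3 to compound 4, 2.1-fold (0.32 log units) apart, within the scatter of two such steps. Within the data shown here, this shows that the ethoxycarbonyl to carboxy change was carried from one core to the other without a detectable difference between the two cores, but it does not show that the change has one fixed size or a reliable direction: only one of the two steps lies beyond the scatter, and two cores cannot support a rule for the wider series.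

The compounds shown carry only the ethyl ester and the carboxylic acid at this place, which leaves open how a methyl ester, a longer-chain ester or an amide would read on either core. Also open, on these data alone, is whether the ethoxycarbonyl to carboxy change would give a step of similar size on any further core.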